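A few compounds are considered here, and "the series" means these few. Any claim that something is new, unique, unknown or untested is made for them only; others in the source may bear on it.

In a functional assay on CCRF-CEM cells (Homo sapiens) for antiproliferative activity, with a stated time of 72 h (on this read-out lower numbers stand for stronger inhibition and higher numbers for weaker inhibition), compound 1 `COc1cc(CNc2ncnc3c2ncn3[C@@H]2O[C@H](CO)[C@@H](O)[C@H]2O)cc(OC)c1` gives > 166000 nM, which is a limit and not a number. For the measured compounds named here, compound 2 `OC[C@H]1O[C@@H](n2cnc3c(NCc4ccc(F)c(F)c4F)ncnc32)[C@H](O)[C@@H]1O` gives 58200 nM, the only true number so far. Compound 3 `OC[C@H]1O[C@@H](n2cnc3c(NCc4c(F)ccc(F)c4F)ncnc32)[C@H](O)[C@@H]1O` has the same atoms joined differently: 2,3,6-trifluorophenyl in place of 2,3,4-trifluorophenyl on a saturated chain carbon bound to a nitrogen on an aromatic ring, with 2,3,6-trifluorophenyl in place of 2,3,4-trifluorophenyl. Going by the values given here, the one measured step, an at least 2.8-fold lower number from compound 1 to compound 2 (0.45 log units; beyond the scatter), exchanged 3,5-dimethoxyphenyl for 2,3,4-trifluorophenyl, a different kind of change that says little about this one, so no step beyond the scatter is expected in this assay. The estimated step is a 1.1-fold lower number from compound 2 to compound 3 (0.02 log units; within the scatter). For compound 3 the expected value is 55000 nM, with an estimated range from 18000 nM to 160000 nM.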

Compound 3, half-maximal inhibitory concentration: 90300 nM
Estimate against measurement, compound 3: 1.6-fold (0.22 log units) below; low and high end bracket the measured number.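

In this assay, rearranging the fluorines from 2,3,4-trifluorophenyl to 2,3,6-trifluorophenyl on this saturated chain carbon gives a 1.6-fold higher number from compound 2 to compound 3 (0.19 log units; within the scatter), so this arrangement of the three fluorines makes no readable difference here. Replacing 3,5-dimethoxyphenyl with 2,3,6-trifluorophenyl gives an at least 1.8-fold lower number from compound 1 to compound 3 (0.26 log units; that floor lies within the scatter), and that floor alone does not separate the two groups. Compound 1 stands at a limit and not a number: the limit of > 166000 nM in this assay, at which 1 of the 3 values shown sits.

The compounds shown leave open whether a phenyl carrying an amine or a carboxylic acid in place of the fluorines would move the number beyond the scatter.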